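A few compounds are considered here, and "the series" means these few. Any claim that something is new, unique, unknown or untested is made for them only; others in the source may bear on it.

In a functional assay on HCT-116 cells (Homo sapiens) for inhibition, read by MTT assay, with a stated time of 72 h (a higher number here means a weaker inhibitor, a lower number a stronger inhibitor), three compounds sharing a core have been measured. Compound 2 `COc1cc(Oc2cccc(Nc3ccccc3)c2)cc(OC)c1CNCc1ccc(C)cc1` gives 13800 nM and compound 1 `COc1cc(Oc2cccc(Nc3ccccc3)c2)cc(OC)c1CNCCNC(C)=O` gives 18200 nM, so these two lie within the usual scatter of each other. Compound 3 `COc1ccc([C@@H](C)NCc2c(OC)cc(Oc3cccc(Nc4ccccc4)c3)c(OC)c2OC)cc1`, which differs from them in more than one place, gives a clearly lower number, 2440 nM.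

Compound 4 `COc1cc(Oc2cccc(Nc3ccccc3)c2)cc(OC)c1CNC(C)C` has not been measured yet. Among the measured compounds shown here, it keeps the core of compound 2, and the one change is isopropyl in place of 4-methylbenzyl on an amine nitrogen.

For the measured compounds named here, the closest evidence is the single measured step, a 1.3-fold lower number from compound 1 to compound 2 (0.12 log units; within the scatter). There, 4-methylphenyl replaces acetamidomethyl on the chain bound to the same amine nitrogen, so a group with a ring and one without it gave numbers that cannot be told apart. Compound 4 also loses the ring, so no step beyond the scatter is expected in this assay. Compound 3, at 2440 nM, shows that a lower number is possible with this kind of core, but one step is thin evidence, so the range stays wide.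

The estimated step is a 1.1-fold higher number from compound 2 to compound 4 (0.04 log units; within the scatter), which would lie within the scatter.

Compound 4 is expected at about 15000 nM, with an estimated range from 5000 nM to 40000 nM.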

Compound 4, half-maximal inhibitory concentration: > 20000 nM
Compound 4 gave a limit, no number; the forecaster's own chance of this, stated with the estimate: 5%; middle value at least 1.3-fold (0.12 log units) away from the limit.
By their numbers in this assay, from the lowest: compound 3; then compounds 2 and 1 (each within the scatter of the next). At a limit, above all of these: compound 4.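

In this assay compound 4 gives a limit of the assay and no number: the limit of > 20000 nM in this assay, at which 1 of the 4 values shown sits. As far as these compounds go, on this amine nitrogen, the change to isopropyl gives an at least 1.4-fold higher number from compound 2 to compound 4 (0.16 log units; that floor lies within the scatter) when it replaces 4-methylbenzyl, and an at least 1.0-fold higher number from compound 1 to compound 4 (0.04 log units; that floor lies within the scatter) when it replaces 2-acetamidoethyl, so each step has only a floor and its true size stays unknown. Among the compounds shown here, what is new is the first view of a small branched group at this position: with 3 heavy atoms and no ring, isopropyl brought no drop in the number from that of compound 2, though the floors alone cannot show that the number truly rose.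

Isopropyl removes the aromatic ring and 5 heavy atoms in one change, so these compounds cannot separate the part played by the ring from the part played by the size of the group. Cyclohexylmethyl, which keeps a ring without aromaticity, plain benzyl, or a longer straight carbon chain on the same nitrogen could pull these apart, and a carboxylic acid on that chain would test a different kind of group altogether.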